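Phenoxy in place of hydroxy on the ethoxy analogue

A few compounds are considered here, and "the series" means these few. Any claim that something is new, unique, unknown or untested is made for them only; others in the source may bear on it.

Measured so far, in a functional assay on MCF7 cells (Homo sapiens) for inhibition, read by resazurin assay, with a stated time of 72 h; on this read-out higher numbers stand for weaker inhibition and lower numbers for stronger inhibition:
compound 1 `COc1ccc(C2C(O)C(=O)N2c2cc(OC)c(OC)c(OC)c2)cc1`: 4 nM
compound 2 `COc1ccc(C2C(Oc3ccccc3)C(=O)N2c2cc(OC)c(OC)c(OC)c2)cc1`: 23 nM
compound 3 `CCOc1ccc(C2C(O)C(=O)N2c2cc(OC)c(OC)c(OC)c2)cc1`: 7 nM

Compound 1 and compound 2 share a core and differ only in one place; the difference is phenyl in place of hydrogen on an oxygen on a saturated carbon. That change gave a 5.8-fold higher number from compound 1 to compound 2 (0.76 log units; beyond the scatter).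

Compound 3 differs from compound 1 in a different place; the difference is methyl in place of hydrogen on a saturated chain carbon bound to an oxygen on an aromatic ring. The step was a 1.8-fold higher number from compound 1 to compound 3 (0.24 log units; within the scatter), so compound 1 and compound 3 are not separated here.

Compound 4 `CCOc1ccc(C2C(Oc3ccccc3)C(=O)N2c2cc(OC)c(OC)c(OC)c2)cc1` is not yet measured. It differs from compound 3 by phenyl in place of hydrogen on an oxygen on a saturated carbon. The place of this change is the same, word for word, as the place of the change from compound 1 to compound 2, so the two changes are the same change, made on cores that differ as told above. Among the compounds shown the change occurs twice in all.

Going by the values given here, for compound 4 the expectation in this assay rests on the single earlier example: the step is expected to be about a 5.7-fold higher number from compound 3 to compound 4 (0.76 log units; beyond the scatter), close to the size seen as a 5.8-fold higher number from compound 1 to compound 2 (0.76 log units; beyond the scatter). That expectation rests on one pair only; whether the core change from compound 1 to compound 3 alters the size of the step is not known from these data.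

Compound 4 is therefore estimated at 40 nM, with a range from 15 nM to 110 nM.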

Compound 4, half-maximal inhibitory concentration: 69 nM
The estimate for compound 4 lay 1.7-fold (0.24 log units) below the measured number; measured number inside the range.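

In this assay the change from hydroxy to phenoxy gives a 9.9-fold higher number from compound 3 to compound 4 (0.99 log units; beyond the scatter), so the number rises on both cores and the two steps are not separated: the same change on two cores in this assay, a 5.8-fold higher number (0.76 log units; beyond the scatter) from compound 1 to compound 2 and a 9.9-fold higher number (0.99 log units; beyond the scatter) from compound 3 to compound 4, 1.7-fold (0.23 log units) apart, within the scatter of two such steps

Methyl in place of hydrogen on the chain carbon, read on the phenoxy compounds, gives a 3.0-fold higher number from compound 2 to compound 4 (0.48 log units; beyond the scatter); this step lies beyond the scatter and its partner within it, yet the two are not separated either: the same change on two cores in this assay, a 1.8-fold higher number (0.24 log units; within the scatter) from compound 1 to compound 3 and a 3.0-fold higher number (0.48 log units; beyond the scatter) from compound 2 to compound 4, 1.7-fold (0.23 log units) apart, within the scatter of two such steps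

Across these four compounds the two changes therefore behave as roughly independent, but each comparison rests on one pair of cores only, and this does not show that either step would keep its size on a further core.

Open, on these data alone, is how other groups on that oxygen would compare with hydroxy and phenoxy, for instance a methyl ether or a benzyl ether, or an amine in place of the oxygen-linked group. Also open, as far as these compounds go, is whether a longer chain such as propoxy in place of ethoxy would leave the phenoxy step the same, and whether any of these steps holds outside this assay.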